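The source may hold more compounds than are shown below. What is called first, only, known or untested is meant among the compounds shown, and "the series" means these compounds.

The measured compounds in a functional assay on HL-60 cells (Homo sapiens) for inhibition; on this read-out higher numbers stand for weaker inhibition and lower numbers for stronger inhibition:
Compound 1 `COc1cc(/C=C\c2ccc(N(C)C)c([N+](=O)[O-])c2)cc(OC)c1OC` gives only a limit of this assay, > 5000 nM.
Compound 2 `COc1cc(/C=C\c2ccc(N(C)C)c(N)c2)cc(OC)c1OC` gives 3 nM.
Compound 3 `COc1cc(/C=C/c2ccc3ccccc3c2)cc([N+](=O)[O-])c1OC` gives only a limit of this assay, > 10000 nM.

Compound 2 differs from compound 1 by amino in place of nitro on an aromatic carbon, and this step gave an at least 1600-fold lower number from compound 1 to compound 2 (3.22 log units; beyond the scatter), with compound 1 sitting at the limit of > 5000 nM in this assay, at which 1 of the 3 values shown sits. Compound 3 sits at the limit of > 10000 nM in this assay, at which 1 of the 3 values shown sits; how its core differs from that of compound 1 is not broken down here. Compound 4 `COc1cc(/C=C/c2ccc3ccccc3c2)cc(N)c1OC` differs from compound 3 by amino in place of nitro on an aromatic carbon, the same kind of change, but here the place is ortho to a methoxy group and meta to a methoxy group rather than ortho to a dimethylamino group. A step of about an at least 330-fold lower number from compound 3 to compound 4 (2.52 log units; beyond the scatter) is expected from compound 3 to compound 4, resting on the step of an at least 1600-fold lower number from compound 1 to compound 2 (3.22 log units; beyond the scatter) seen in compound 1 and compound 2. Compound 4 is therefore estimated at 30 nM, between 4 nM and 600 nM.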

Compound 4, half-maximal inhibitory concentration: 3150 nM
Beside the measured number, compound 4's estimate is 110-fold (2.02 log units) below it; the measured number lies above the stated range.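

In this assay, amino in place of nitro on an aromatic carbon lowers the number again, an at least 3.1-fold lower number from compound 3 to compound 4 (0.50 log units; beyond the scatter), so the direction of the change holds on both cores shown. Compound 3 gives only a limit, > 10000 nM. What this does not show is whether the size of the change carries from one core to the other: the same change on two cores in this assay, an at least 1600-fold lower number (3.22 log units; beyond the scatter) from compound 1 to compound 2 and an at least 3.1-fold lower number (0.50 log units; beyond the scatter) from compound 3 to compound 4; the limit leaves it open whether they differ

The compounds shown leave open what a hydroxyl group or an acetamide would give in place of the amino group on either core. From the compounds shown here alone, it also remains open whether the same change would follow this direction on a third core.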